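Extending the alkyl chain from compound 3 to compound 4

The source may report more compounds than this note shows. Statements on the series, on what has been measured and on what is new or still open speak of the compounds shown alone.

compound 1 `CCCCCCCCCCOC1=C(O)OC(C(O)CO)C1=O` 13000 nM
compound 2 `CCCCCCCCCCCOC1=C(O)OC(C(O)CO)C1=O` 13000 nM
compound 3 `CCCCCCCCCCCCCCOC1=C(O)OC(C(O)CO)C1=O` 7400 nM

All three values come from a functional assay (brain) for inhibition, with Rattus norvegicus as the target; a lower number here means a stronger inhibitor, a higher number a weaker inhibitor. Compound 3 stands within the scatter of both other compounds, as a 1.8-fold lower number from compound 1 to compound 3 (0.24 log units; within the scatter) and a 1.8-fold lower number from compound 2 to compound 3 (0.24 log units; within the scatter) show. The remaining measured step, no change at the digits printed from compound 1 to compound 2 (within the scatter), also stays within the scatter.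

The next member is compound 4 `CCCCCCCCCCCCCCCCCCCCOC1=C(O)OC(C(O)CO)C1=O`, and the change is hexyl in place of hydrogen on a saturated chain carbon, ten or more bonds along the chain from an oxygen on an unsaturated carbon. All three measured steps bear on it, since each adds to the chain at the same kind of place. The largest group added among them is butyl, in a 1.8-fold lower number from compound 1 to compound 3 (0.24 log units; within the scatter), so hexyl goes beyond the range sampled so far. Going by the values given here, no measured step exceeds the scatter, so no step beyond the scatter is expected in this assay, and no direction is favoured. The expected change is a 1.1-fold higher number from compound 3 to compound 4 (0.03 log units; within the scatter). The estimate for compound 4 is 8000 nM, with an expected range of 3000 nM to 25000 nM.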

Compound 4, half-maximal inhibitory concentration: 4700 nM
Beside the measured number, compound 4's estimate is 1.7-fold (0.23 log units) above it; the range from low to high includes it.
By their numbers in this assay, from the lowest: compounds 4, 3, 1 and 2 (each within the scatter of the next, the first and the last beyond it).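

In this assay, going by these compounds alone, the only steps that pass the scatter are the two widest chain differences (a 2.8-fold lower number from compound 2 to compound 4 (0.44 log units; beyond the scatter); a 2.8-fold lower number from compound 1 to compound 4 (0.44 log units; beyond the scatter)), so a gain of nonyl or decyl at this place on the chain registers, though modestly. The hexyl step alone stays inside the scatter (a 1.6-fold lower number from compound 3 to compound 4 (0.20 log units; within the scatter)), so the series separates only between its ends, and compound 4 does not separate from compound 3. No measurement in hand speaks to what lies behind this.

As far as these compounds go, whether a longer chain than that of compound 4 goes on lowering the number remains open, as does the outcome of an amine or a carboxylic acid at the chain end. The shared core is the same throughout, so nothing here tests a change to it.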